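This account rests on a few compounds, and the source may have more. Where it says the series, first, only, none or still open, it means among the compounds named here.

The measured compounds:
compound 1 `Cc1ccc(C(=O)/C=C/c2ccc(/C=N/NC(=O)c3ccncc3)cc2)c(C)c1` — 58.5%
compound 2 `O=C(/C=C/c1ccc(/C=N/NC(=O)c2ccncc2)cc1)c1ccc(Br)cc1` — 55.7%

In a functional assay on the whole organism (Ear) for inhibition, with Mus musculus as the target, with a stated time of 30 min, at a dose of 100 mg/kg by the intraperitoneal route (a lower number here means less inhibition, a higher number more inhibition at the dose given (going by the name of the read-out)), compound 1 gives 58.5%, and compound 2 gives 55.7%. Compound 2 sits nearest to compound 1 among the two numbers, and the step of a number 2.8 percentage points lower from compound 1 to compound 2 (within the scatter) lies within the scatter, so the two cannot be told apart on these data.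

Compound 3 `O=C(N/N=C/c1ccc(/C=C/C(=O)c2ccccc2F)cc1)c1ccncc1` differs from compound 2 at one place only: 2-fluorophenyl in place of 4-bromophenyl on a carbonyl carbon. For the measured compounds named here, the only measured step that bears on this change is a number 2.8 percentage points lower from compound 1 to compound 2 (within the scatter), which also exchanged the aromatic ring on a carbonyl carbon and moved the read-out by no more than the scatter. On that basis no step beyond the scatter is expected, and the expected step of a number 0.7 percentage points lower from compound 2 to compound 3 (within the scatter) is put at about nothing. Compound 3 is therefore estimated to give about 55%, between 40% and 68%, in this assay.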

Compound 3, a percentage reported as inhibition, in the whole organism at one dose (the size of the read-out at that dose, not a potency): 51.3%
For compound 3 the middle estimate is 3.7 percentage points above the measured one; measured number inside the range.
By their numbers in this assay, from the lowest: compounds 3, 2 and 1 (each within the scatter of the next).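

In this assay, the change from 4-bromophenyl to 2-fluorophenyl on a carbonyl carbon amounts to a number 4.4 percentage points lower from compound 2 to compound 3 (within the scatter), and the change from 2,4-dimethylphenyl to 2-fluorophenyl amounts to a number 7.2 percentage points lower from compound 1 to compound 3 (within the scatter). At this position, then, a third substituted phenyl group, now carrying fluorine, still cannot be told apart from the other two, and all three pairs among these compounds lie within the scatter. Nothing measured here offers an explanation for these numbers.

The compounds shown leave open whether a group of another kind on this carbonyl carbon, such as an aminophenyl, a carboxyphenyl or a plain alkyl chain, would move the read-out beyond the scatter. They also leave open how these compounds would compare at any other dose.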